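The source may report more compounds than this note shows. Statements on the series, on what has been measured and on what is new or still open speak of the compounds shown alone.

In a functional assay on NCI-H23 cells (Homo sapiens) for antiproliferative activity, read by XTT assay (a lower number here means a stronger inhibitor, a higher number a weaker inhibitor), compound 1 `O=c1c(Cc2coc3cccc(OCC4CCCCC4)c3c2=O)coc2ccccc12` gives 4130 nM. Compound 2 `O=c1c(Cc2coc3cccc(OCC4CCCCC4)c3c2=O)coc2cc(Cl)ccc12`, which adds a chloro group on an aromatic carbon, gives > 10000 nM. That value is a limit of the assay and not a number. Compound 3 `COc1ccc2c(=O)c(Cc3coc4cccc(OCC5CCCCC5)c4c3=O)coc2c1`, which carries a methoxy group instead, gives 1320 nM, the lowest number of the three and so the strongest inhibitor among them.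

Compound 4 `O=c1c(Cc2coc3cccc(OCC4CCCCC4)c3c2=O)coc2cc(O)ccc12` has not yet been measured. It differs from compound 3 by one small change hydrogen in place of methyl on an oxygen on an aromatic ring, which turns methoxy into hydroxy. Among the compounds with values here, no measured step makes this exact change, so the evidence is indirect. Adding methoxy gave a 3.1-fold lower number from compound 1 to compound 3 (0.50 log units; beyond the scatter), and replacing chloro with methoxy gave an at least 7.5-fold lower number from compound 2 to compound 3 (0.87 log units; beyond the scatter). Adding chloro gave an at least 2.4-fold higher number from compound 1 to compound 2 (0.38 log units; beyond the scatter). Swapping the group on this aromatic carbon has therefore moved the number in both directions.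

Compound 4 keeps the oxygen of compound 3 and loses only the methyl, so it is expected to lose part of the gain seen in a 3.1-fold lower number from compound 1 to compound 3 (0.50 log units; beyond the scatter). In this assay, the expected change is small and upward, a 1.9-fold higher number from compound 3 to compound 4 (0.28 log units; within the scatter). For compound 4 the estimated value is 2500 nM, with an expected range of 700 nM to 8000 nM.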

Compound 4, half-maximal inhibitory concentration: 2150 nM
For compound 4 the middle estimate is 1.2-fold (0.07 log units) above the measured one; low and high end bracket the measured number.
By their numbers in this assay, from the lowest: compounds 3, 4 and 1 (each within the scatter of the next, the first and the last beyond it). At a limit, above all of these: compound 2.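

In this assay, hydrogen in place of methyl on the oxygen gives a 1.6-fold higher number from compound 3 to compound 4 (0.21 log units; within the scatter), so at this position methoxy and hydroxy cannot be told apart, and the methyl is not shown to matter. Hydroxy in place of hydrogen on the aromatic carbon gives a 1.9-fold lower number from compound 1 to compound 4 (0.28 log units; within the scatter), which places compound 4 within the scatter of both its neighbours, even though those two are separated beyond the scatter by a 3.1-fold lower number from compound 1 to compound 3 (0.50 log units; beyond the scatter). Hydroxy in place of chloro gives an at least 4.6-fold lower number from compound 2 to compound 4 (0.66 log units; beyond the scatter), so both oxygen-bearing groups stand clear of chloro, although this step gives a bound and not an exact size, since one of its two values is a limit of the assay and not a number: the limit of > 10000 nM in this assay, at which 1 of the 4 values shown sits.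

As far as these compounds go, it remains open whether the oxygen itself matters: an amine on this aromatic carbon would test that, and ethoxy, a longer chain on the same oxygen, would show whether a group larger than methoxy is tolerated. From the compounds shown here alone, it also remains open whether the poor result with chloro is particular to chloro or extends to another halogen such as fluoro.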